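Methyl Removal on the Pyrazol-1-yl Ring: Two Pairs

The source may report more compounds than this note shows. Statements on the series, on what has been measured and on what is new or still open speak of the compounds shown alone.

Compound 1 `Cc1cnn(C(=O)N2CCCCC2)c1` and compound 2 `O=C(N1CCCCC1)n1cccn1` share one core; compound 2 differs from compound 1 by hydrogen in place of methyl on an aromatic carbon. In an assay on membranes from brain for binding affinity to Monoglyceride lipase (Mus musculus), read by fluorescence, with stated times of 1 h and 30 min (a lower number here means a stronger inhibitor, a higher number a weaker inhibitor), compound 1 gives 9200 nM, and compound 2 gives 6600 nM; the step is a 1.4-fold lower number from compound 1 to compound 2 (0.14 log units; within the scatter). Compound 3 `Cc1cnn(C(=O)N2CCCN(Cc3ccc(OCc4ccccc4)cc3)CC2)c1` sits on a different core, and the difference between its core and the core of compound 1 is not broken down here. In this assay compound 3 gives 9500 nM, which lies within the scatter of both compound 1 and compound 2. Compound 4 `O=C(N1CCCN(Cc2ccc(OCc3ccccc3)cc2)CC1)n1cccn1` is the unmeasured partner of compound 3 and differs from it by hydrogen in place of methyl on an aromatic carbon. This is the same kind of change as that from compound 1 to compound 2, though the surroundings differ: in the first pair the ring atom bears a group of 8 heavy atoms, in the second pair it bears a large group. Compound 4 is expected at 7000 nM, with a range from 3500 nM to 14000 nM. The expected step of a 1.4-fold lower number from compound 3 to compound 4 (0.13 log units; within the scatter) rests on compound 3 at 9500 nM carried forward by the earlier step of a 1.4-fold lower number from compound 1 to compound 2 (0.14 log units; within the scatter), which stayed within the scatter.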

Compound 4, half-maximal inhibitory concentration: 10000 nM
Compound 4: middle estimate off by 1.4-fold (0.15 log units), on the low side, and the stated range covers the measured number.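

In this assay, the change from 4-methyl-1H-pyrazol-1-yl to 1H-pyrazol-1-yl gives a 1.1-fold higher number from compound 3 to compound 4 (0.02 log units; within the scatter), so removing the methyl has no readable effect on this second core either. Set beside the earlier step, the result on the two cores does not differ: the same change on two cores in this assay, a 1.4-fold lower number (0.14 log units; within the scatter) from compound 1 to compound 2 and a 1.1-fold higher number (0.02 log units; within the scatter) from compound 3 to compound 4, 1.5-fold (0.17 log units) apart, within the scatter of two such steps Within these two pairs the change therefore carries from one core to the other as a step too small to read, but this shows neither a shared size nor a shared direction for the step, and it says nothing about how a change with a readable effect would carry across these cores.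

The compounds shown leave open whether a different group on this aromatic carbon, such as trifluoromethyl, a nitrile or a carboxylic acid, would give a step beyond the scatter on either core. Also open, as far as these compounds go, is whether a longer chain, such as ethyl or propyl, in place of the methyl would do so.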